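Does a benzoyl group keep compound 3 tolerated?

The source may hold more compounds than are shown below. What is called first, only, known or untested is meant among the compounds shown, and "the series" means these compounds.

Measured in a functional assay on HEL cells (Homo sapiens); a higher number here means that more compound is tolerated, a lower number that less compound is tolerated:
- compound 1 `Cc1cn([C@@H]2O[C@H](CO[Si](C)(C)C(C)(C)C)[C@@]3(OS(=O)(=O)C=C3NCC(=O)C(=O)N3CCC3)[C@H]2O[Si](C)(C)C(C)(C)C)c(=O)n(C)c1=O`: 84400 nM
- compound 2 `COC(=O)NC1=CS(=O)(=O)O[C@@]12[C@@H](CO[Si](C)(C)C(C)(C)C)O[C@@H](n1cc(C)c(=O)n(C)c1=O)[C@@H]2O[Si](C)(C)C(C)(C)C`: > 200000 nM (a limit)
- compound 3 `Cc1cn([C@@H]2O[C@H](CO[Si](C)(C)C(C)(C)C)[C@@]3(OS(=O)(=O)C=C3NCC(=O)OCc3ccccc3)[C@H]2O[Si](C)(C)C(C)(C)C)c(=O)n(C)c1=O`: > 200000 nM (a limit)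

Compound 3 has no exact number, only a limit: > 200000 nM. It shares this ceiling with compound 2, as the limit of > 200000 nM in this assay, at which 2 of the 3 values shown sit, shows. Only compound 1 has a measured number.

Compound 4 `Cc1cn([C@@H]2O[C@H](CO[Si](C)(C)C(C)(C)C)[C@@]3(OS(=O)(=O)C=C3NC(=O)c3ccccc3)[C@H]2O[Si](C)(C)C(C)(C)C)c(=O)n(C)c1=O` carries benzoyl in place of (benzyloxycarbonyl)methyl on an amine nitrogen. The closest comparison changes that same nitrogen, but it shows a step that the two limits leave unreadable from compound 2 to compound 3, so it gives no size to borrow. The other two steps both start from compound 1 and end at the limit. One is an at least 2.3-fold higher number from compound 1 to compound 2 (0.37 log units; beyond the scatter), and it is the more useful, since methoxycarbonyl, like benzoyl, places a carbonyl on that nitrogen. The other is an at least 2.3-fold higher number from compound 1 to compound 3 (0.37 log units; beyond the scatter). Both are modest at minimum, and neither shows a fall from the limit. Going by the values given here, no measured compound carries benzoyl, so the expectation remains loose.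

The estimated step is a number no higher from compound 3 to compound 4 (the limit leaves the size open), so no change beyond the scatter is expected in this assay. For compound 4 the expected value is 200000 nM, with an estimated range from 90000 nM to 400000 nM.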

Compound 4, half-maximal cytotoxic concentration: 9700 nM
Compound 4: middle estimate off by 21-fold (1.31 log units), on the high side; the whole stated range lies above it.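

In this assay, the group on this amine nitrogen clearly matters, and swapping (benzyloxycarbonyl)methyl for benzoyl gives an at least 20-fold lower number from compound 3 to compound 4 (1.31 log units; beyond the scatter), even though both groups contain the same kind of aromatic ring. A carbonyl on the nitrogen is also not enough to keep the number high: with phenyl in place of methoxy on that carbonyl carbon, there is an at least 20-fold lower number from compound 2 to compound 4 (1.31 log units; beyond the scatter). The only other exact value gives an 8.7-fold lower number from compound 1 to compound 4 (0.94 log units; beyond the scatter), which makes the benzoyl compound the least tolerated of the four, while the two larger steps are only minimum sizes that start from a limit: the limit of > 200000 nM in this assay, at which 2 of the 4 values shown sit.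

The step between the two compounds at the limit cannot be read, so nothing orders them against each other. As far as these compounds go, it remains open whether the fall needs the phenyl ring directly on the carbonyl, which a phenylacetyl group with its longer chain or a plain acetyl group on the same nitrogen could help to separate.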